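Extending a Side Chain on a Kinase Inhibitor Core

This account rests on a few compounds, and the source may have more. Where it says the series, first, only, none or still open, it means among the compounds named here.

Of the compounds shown here, two have so far been measured in an assay for inhibition of Rho-associated protein kinase 1 (Homo sapiens), read by TR-FRET, with stated times of 5 min and 2 h; on this read-out higher numbers stand for weaker inhibition and lower numbers for stronger inhibition. Compound 1 `CCc1n[nH]cc1-c1cc2c(s1)C(=O)NC(C)(C)N2C` gives 350 nM. Compound 2 `CCC1(C)NC(=O)c2sc(-c3ccncc3)cc2N1` gives 36 nM, the lowest of the two numbers; the gap between compound 1 and compound 2 lies beyond the usual scatter of the method, so compound 2 is the stronger inhibitor of the pair. Going by the values given here, no single-point step can be drawn between them, because they differ in more than one place.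

Compound 3 `CCCC1(C)NC(=O)c2sc(-c3ccncc3)cc2N1` has not yet been measured. It differs from compound 2 in one place: methyl in place of hydrogen on a saturated chain carbon, two bonds along the chain from a saturated ring carbon, so the ethyl chain of compound 2 becomes a propyl chain. Among the compounds with values here, nothing among the measured compounds shows what lengthening this chain does, so the direction of the step cannot be read from them. Such a small addition is expected to move the number only a little, and the step of a 1.4-fold higher number from compound 2 to compound 3 (0.14 log units; within the scatter) is expected to stay within the scatter. The estimate for compound 3 in this assay is 50 nM, with a range from 15 nM to 160 nM.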

Compound 3, half-maximal inhibitory concentration: 33 nM
Estimate against measurement, compound 3: 1.5-fold (0.18 log units) above; the range from low to high includes it.
By their numbers in this assay, from the lowest: compounds 3 and 2 (each within the scatter of the next); then compound 1.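

Going from ethyl to propyl on this chain gives a 1.1-fold lower number from compound 2 to compound 3 (0.04 log units; within the scatter) in this assay and is the first direct reading of what this position does, which compound 1 and compound 2 could not offer because they differ in more than one place. The added methyl, two bonds along the chain from a saturated ring carbon, leaves compound 2 and compound 3 indistinguishable by this method, so at this position the chain can carry that one extra carbon with the two numbers staying within the scatter of each other. No measurement at hand gives a reason for this outcome.

A single step cannot establish a trend along the chain, and a longer chain such as butyl, a branched chain such as isopropyl, or a chain ending in an amine or a carboxylic acid may read quite differently here. The compounds shown also leave open whether the same extension would give a similar reading on the core of compound 1, which carries a different set of groups.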